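The source may report more compounds than this note shows. Statements on the series, on what has been measured and on what is new or still open speak of the compounds shown alone.

Measured so far in an in vitro assay on AV12 cells for binding affinity to Neuropeptide Y receptor type 1 (Homo sapiens); on this read-out higher numbers stand for weaker inhibition and lower numbers for stronger inhibition:
compound 1 `c1ccc(OCc2nc3c(OCCCN4CCCCC4)cccc3n2CCCC2CCN(CCCN3CCCCC3)CC2)cc1`: 0.106 nM
compound 2 `O=C(CCN1CCC(CCCn2c(COc3ccccc3)nc3c(OCCCN4CCCCC4)cccc32)CC1)c1ccccc1`: 0.112 nM
compound 3 `CC(C)CCN1CCC(CCCn2c(COc3ccccc3)nc3c(OCCCN4CCCCC4)cccc32)CC1`: 0.29 nM

Compound 3 gives the highest number of the three in this assay. Its nearest neighbour is compound 2, and the gap to compound 1 is of the same order; both gaps lie beyond the scatter.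

Compound 4 `O=C(CCCN1CCC(CCCn2c(COc3ccccc3)nc3c(OCCCN4CCCCC4)cccc32)CC1)c1ccccc1` is not yet measured. It differs from compound 3 in one place: benzoylmethyl in place of isopropyl on a saturated chain carbon, two bonds along the chain from an amine nitrogen in a ring. The benzoylmethyl tail of compound 4 carries one chain carbon more than the benzoyl tail of compound 2, otherwise the two compounds are alike.

Going by the values given here, two measured steps bear on the change. a 2.6-fold higher number from compound 2 to compound 3 (0.41 log units; beyond the scatter) is the direct reverse of the new step, apart from the extra chain carbon. a 2.7-fold higher number from compound 1 to compound 3 (0.44 log units; beyond the scatter) points the same way. a 1.1-fold higher number from compound 1 to compound 2 (0.02 log units; within the scatter) shows that a benzoyl tail and a (piperidin-1-yl)methyl tail read alike within the scatter, while the isopropyl compound stands apart from both. Among the compounds with values here, the extra chain carbon has no counterpart among the measured compounds, which widens the range.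

The expected step from compound 3 is a 2.1-fold lower number from compound 3 to compound 4 (0.32 log units; beyond the scatter), back toward compound 2. Compound 4 is therefore estimated at 0.14 nM, with a range of 0.06 nM to 0.35 nM.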

Compound 4, inhibition constant: 0.132 nM
Compound 4: the middle estimate sits 1.1-fold (0.03 log units) above what was measured; low and high end bracket the measured number.
By their numbers in this assay, from the lowest: compounds 1, 2 and 4 (each within the scatter of the next); then compound 3.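

In this assay the benzoylmethyl tail gives a 2.2-fold lower number from compound 3 to compound 4 (0.34 log units; beyond the scatter), so the separation of the isopropyl compound from the benzoyl compound is not confined to a single benzoyl chain length. Going by these compounds alone, the two carbonyl-bearing tails cannot be told apart here, with a 1.2-fold higher number from compound 2 to compound 4 (0.07 log units; within the scatter), so at this position the series so far shows no sensitivity to the change from benzoyl to benzoylmethyl. With a 1.2-fold higher number from compound 1 to compound 4 (0.10 log units; within the scatter) also inside the scatter, a tail ending in benzoyl and one ending in piperidin-1-yl read alike at the same chain length, and among the four compounds only compound 3, with its isopropyl tail, stands apart from the rest.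

No measurement to hand accounts for these readings or for the position of compound 3. On these data alone, it remains open whether the carbonyl itself matters or only the presence of an aromatic ring or amine at the end of the tail, which a 3-phenylpropyl tail could separate, and whether a still longer chain ending in benzoyl, or a tail ending in a carboxylic acid, would stay with compounds 1, 2 and 4 or fall with compound 3.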